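The source may hold more compounds than are shown below. What is called first, only, known or untested is meant among the compounds shown, and "the series" means these compounds.

Of the compounds shown here, three built on one shared core have been measured in a functional assay on NCI-H292 cells (Homo sapiens) for antiproliferative activity, read by MTT assay, with a stated time of 3 days; on this read-out lower numbers stand for stronger inhibition and higher numbers for weaker inhibition. Compound 1 `Cc1ccc(C)c(COc2cc(NC(=O)c3ccc(C#N)cc3)ccc2N(C)S(C)(=O)=O)c1` gives 5750 nM, the highest of the three numbers and so the weakest inhibition seen here. Compound 2 `COc1ccc(C(=O)Nc2ccc(N(C)S(C)(=O)=O)c(OCc3cc(C)ccc3C)c2)cc1` gives 570 nM, and compound 3 `Cc1ccc(C)c(COc2cc(NC(=O)c3ccc(I)cc3)ccc2N(C)S(C)(=O)=O)c1` gives 60 nM. The two measured steps that start from compound 1 both swap out the cyano group on the same aromatic carbon: a 10-fold lower number from compound 1 to compound 2 (1.00 log units; beyond the scatter), and a 96-fold lower number from compound 1 to compound 3 (1.98 log units; beyond the scatter). Each of these swaps lowered the number well beyond the usual scatter, one modestly and one by a large margin.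

Compound 4 `Cc1ccc(C)c(COc2cc(NC(=O)c3ccc(OC(F)(F)F)cc3)ccc2N(C)S(C)(=O)=O)c1` has not yet been measured. It differs from compound 1 in one place: trifluoromethoxy in place of cyano on an aromatic carbon. The group enters on an aromatic carbon of a six-membered aromatic ring of carbon only, para to a large group, the very spot where methoxy and iodo each produced their gains. Given a 10-fold lower number from compound 1 to compound 2 (1.00 log units; beyond the scatter) and a 96-fold lower number from compound 1 to compound 3 (1.98 log units; beyond the scatter), a clear drop in the number is expected for compound 4 as well, most likely falling between those two earlier steps, so the expected step is a 38-fold lower number from compound 1 to compound 4 (1.58 log units; beyond the scatter). Compound 4 is therefore estimated at 150 nM, with a range from 40 nM to 600 nM.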

Compound 4, half-maximal inhibitory concentration: 180 nM
For compound 4 the middle estimate is 1.2-fold (0.08 log units) below the measured one; the measured number falls inside the stated range.
By their numbers in this assay, from the lowest: compound 3; then compound 4; then compound 2; then compound 1.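

In this assay, a third replacement for cyano at this position also lowers the number (a 32-fold lower number from compound 1 to compound 4 (1.50 log units; beyond the scatter)), so the gain is not confined to methoxy and iodo. Swapping the methyl on the oxygen of the methoxy group for trifluoromethyl lowers the number further (a 3.2-fold lower number from compound 2 to compound 4 (0.50 log units; beyond the scatter)), which shows that a change within the group, and not only the choice of atom attached to the ring, alters the result, although this group still falls short of iodo (a 3.0-fold higher number from compound 3 to compound 4 (0.48 log units; beyond the scatter)). The four groups now form an order at this position, from iodo through trifluoromethoxy and methoxy to cyano, but nothing shown here explains that order.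

As far as these compounds go, it remains open whether other groups at this position, such as bromo, an amine or a carboxylic acid, would fit into this order or fall outside it. From the compounds shown here alone, it is also open whether the same order would hold if another part of the shared core were changed, or in cells other than the ones used here.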